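The source may report more compounds than this note shows. Statements on the series, on what has been measured and on what is new or still open speak of the compounds shown alone.

Measured compounds: compound 1 `Cc1n[nH]c(C(=O)O)c1Cc1cccc(-c2ccc(OC(F)(F)F)cc2)c1`, 300 nM; compound 2 `Cc1n[nH]c(C(=O)O)c1Cc1ccc(Oc2ccccc2)cc1`, 500 nM.

In an assay on isolated protein for inhibition of 2-Hydroxyacid oxidase 2 (Rattus norvegicus) (on this read-out lower numbers stand for stronger inhibition and higher numbers for weaker inhibition), compound 1 gives 300 nM and compound 2 gives 500 nM. These two numbers lie within the usual scatter of each other, so compound 1 stands level with compound 2 rather than apart from it. Compound 3 `Cc1n[nH]c(C(=O)O)c1Cc1cccc(-c2ccc(C(=O)O)cc2)c1` has not yet been measured. It differs from compound 1 by carboxy in place of trifluoromethoxy on an aromatic carbon. Among the measured compounds shown here, no measured pair follows this change, so the expectation rests on compound 1 alone: a modest step toward weaker inhibition is expected, a 2.3-fold higher number from compound 1 to compound 3 (0.37 log units; beyond the scatter). Compound 3 is therefore estimated at 700 nM, with a range from 150 nM to 3000 nM.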

Compound 3, half-maximal inhibitory concentration: 1100 nM
Estimate against measurement, compound 3: 1.6-fold (0.20 log units) below; low and high end bracket the measured number.
By their numbers in this assay, from the lowest: compounds 1 and 2 (each within the scatter of the next); then compound 3.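

Carboxy in place of trifluoromethoxy, on the aromatic carbon para to a large group, gives a 3.7-fold higher number from compound 1 to compound 3 (0.56 log units; beyond the scatter) in this assay and is the first step that can be read at this position. The group at this place therefore affects the read-out, and this change weakens inhibition without abolishing it. No measurement shown accounts for the size of this step.

Going by these compounds, how an amide or a nitrile at this same place would compare with trifluoromethoxy and carboxy remains open.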